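This account rests on a few compounds, and the source may have more. Where it says the series, first, only, none or still open, it means among the compounds named here.

Of the compounds shown here, two of one shared core have been measured. Compound 1 `COc1cc(-c2ccnc3cc(-c4cn(CO)c5ccccc45)nn23)cc(OC)c1OC` carries a bicyclic group on the core, and in a functional assay on B16-F0 cells (Mus musculus) for inhibition, read by CCK-8 assay, with a stated time of 48 h (a higher number here means a weaker inhibitor, a lower number a stronger inhibitor), compound 1 gives 93 nM. Compound 2 `COc1cc(-c2ccnc3cc(-c4ccccc4)nn23)cc(OC)c1OC` carries a plain phenyl at the same place, and in this assay compound 2 gives 4730 nM. Of the two numbers, compound 2 holds the higher one, and the gap to compound 1 lies well beyond the usual scatter, so compound 2 is the weaker inhibitor of the pair.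

Compound 3 `COc1cc(-c2ccnc3cc(-c4ccc5ccn(C)c5c4)nn23)cc(OC)c1OC` differs from compound 2 in one place: 1-methyl-1H-indol-6-yl in place of phenyl on an aromatic carbon. For the measured compounds named here, no measured pair shows exactly this swap, yet the bicyclic group of compound 1 went with the far lower value 93 nM, so the step is expected to be large and downward, estimated as a 16-fold lower number from compound 2 to compound 3 (1.20 log units; beyond the scatter). Compound 3 is thus expected to give about 300 nM in this assay, with a likely range from 60 nM to 1500 nM.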

Compound 3, half-maximal inhibitory concentration: 657 nM
For compound 3 the middle estimate is 2.2-fold (0.34 log units) below the measured one; the measured number falls inside the stated range.
By their numbers in this assay, from the lowest: compound 1; then compound 3; then compound 2.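

For the compounds shown here, putting 1-methyl-1H-indol-6-yl in place of phenyl on this aromatic carbon gives a 7.2-fold lower number from compound 2 to compound 3 (0.86 log units; beyond the scatter) in this assay and so shows that a second bicyclic group, different from the one in compound 1, also goes with a lower number than phenyl. Having two rings does not settle the value, since compound 3 at 657 nM still stands above compound 1 at 93 nM in this assay and the choice of bicyclic group therefore matters. Nothing given here explains this difference between the two groups.

Still open, as far as these compounds go, is whether the methyl on the ring nitrogen of compound 3 matters, for example if it were replaced by a hydrogen or a longer chain. From the compounds shown here alone, it is also open how a phenyl carrying a single substituent, such as an amine or a carboxylic acid, would compare with these bicyclic groups.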